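The compounds below may be only part of what the source reports. "The series", "measured", "known", "first", "only" and "open" are said of these compounds alone.

Of the compounds shown here, two sharing one core have been measured in an assay on HEK293F cells for inhibition of AP2-associated protein kinase 1 (Homo sapiens), read by Western blot, with a stated time of 3 h; on this read-out lower numbers stand for stronger inhibition and higher numbers for weaker inhibition. Compound 1 `CC(=O)Nc1cc(-c2ccc(OC[C@@](C)(N)CC(C)C)c(F)c2)ccn1` gives 3.7 nM, and compound 2 `CC(=O)Nc1cc(-c2ccc(OC[C@@H](N)CC(C)C)c(F)c2)ccn1` gives 1.6 nM, so compound 2 stands lowest of the two numbers. For the measured compounds named here, the only step seen, a 2.3-fold lower number from compound 1 to compound 2 (0.36 log units; beyond the scatter), concerns the chain carbon bearing the amine. Compound 3 `CC(=O)Nc1cc(-c2ccc(OC[C@@H](N)CC(C)C)cc2)ccn1` differs from compound 2 by hydrogen in place of fluoro on an aromatic carbon. That aromatic position is untouched by any measured step, so nothing shown speaks directly to it. Compound 3 is therefore expected to give 2.5 nM, within 1 nM to 6 nM, an expected step of a 1.6-fold higher number from compound 2 to compound 3 (0.19 log units; within the scatter) near the scatter.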

Compound 3, half-maximal inhibitory concentration: 8.1 nM
Compound 3: the middle estimate sits 3.2-fold (0.51 log units) below what was measured, and the stated range ends below it.
By their numbers in this assay, from the lowest: compound 2; then compound 1; then compound 3.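

On this aromatic carbon, ortho to the (2-amino-4-methylpentyl)oxy group, hydrogen in place of fluoro gives a 5.1-fold higher number from compound 2 to compound 3 (0.70 log units; beyond the scatter) in this assay and shows that the position is sensitive to what it carries. A single fluorine atom separates the lowest number of the three compounds from the highest. Nothing available explains why the number moves. Going by these compounds, whether a chloro or methoxy group on this carbon would match the fluoro remains open. So does whether the same swap would have a similar effect in compound 1, with its extra methyl on the chain carbon.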